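Urea series: bromo in place of trifluoromethyl

The source may hold more compounds than are shown below. What is called first, only, known or untested is meant among the compounds shown, and "the series" means these compounds.

Measured in an ADME assay on the whole organism with Oryza sativa as the target, tested at 1 uM (on this read-out lower numbers stand for a stronger effect and higher numbers for a weaker effect at the one concentration tested), so far:
compound 1, `CCc1ccccc1NC(=O)N[C@H](C)c1ccccc1`, gives 100%;
compound 2, `C[C@@H](NC(=O)Nc1cccc(C(F)(F)F)c1)c1ccccc1`, gives 72%;
compound 3, `C[C@H](NC(=O)Nc1cccc(C(F)(F)F)c1)c1ccccc1`, gives 93%.

Compound 2 stands lowest of the three numbers, that is, with the strongest effect on this read-out; compound 3 is nearest, compound 1 furthest, both beyond the scatter. Among the measured compounds shown here, the only single-point step measured is a number 21 percentage points higher from compound 2 to compound 3 (beyond the scatter), and the pair differs only in the drawn configuration (the fact that compounds 2 and 3 differ only in the configuration as drawn).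

Compound 4, `C[C@@H](NC(=O)Nc1cccc(Br)c1)c1ccccc1`, is not yet measured. Against compound 2 the change is bromo in place of trifluoromethyl on an aromatic carbon, on an aromatic carbon of a six-membered aromatic ring of carbon only, meta to a large group. For the measured compounds named here, none of the measured steps involves a change of this kind; the stereochemical step from compound 2 to compound 3 gives no guide to a substituent swap on the aromatic ring. With nothing to point either way, the expectation is a step of a number 3 percentage points higher from compound 2 to compound 4 (within the scatter), that is, no change beyond the scatter. Compound 4 is therefore estimated at 75%, within 55% to 100%.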

Compound 4, a percentage reported as activity, at one concentration (the size of the read-out at that concentration, not a potency): 100%
The estimate for compound 4 lay 25 percentage points below the measured number, and the stated range covers the measured number.
By their numbers in this assay, from the lowest: compound 2; then compounds 3, 1 and 4 (each within the scatter of the next).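

In this assay, bromo in place of trifluoromethyl on the aromatic carbon meta to a large group gives a number 28 percentage points higher from compound 2 to compound 4 (beyond the scatter), so this place on the ring responds to the group it carries. Among the compounds shown here, the one earlier step that could be read changed only the drawn configuration and said nothing about this substituent. With the configuration of compound 2 held, the lower number of that compound therefore does not carry over to the bromo analogue, and nothing available accounts for the step.

Open, going by these compounds, is whether trifluoromethyl is unusual at this place, or whether a nitrile, a methoxy group or a carboxylic acid there would also give a lower number. Also open, on these data alone, is whether bromo in place of trifluoromethyl would give a similar step in the configuration drawn for compound 3.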